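Swapping Ethoxy for Chloro on the Shared Core

The source may report more compounds than this note shows. Statements on the series, on what has been measured and on what is new or still open speak of the compounds shown alone.

Of the compounds shown here, two have so far been tested in a functional assay on B16-F10 cells (Mus musculus) for cytotoxicity, read by MTT assay, with a stated time of 48 h; a higher number here means a weaker inhibitor, a lower number a stronger inhibitor. Within the data shown here, compound 1 `CCOc1ccc2nc(Nc3nc4ccc(F)cc4s3)sc2c1` gives 33200 nM in this assay, and this is the only definite number recorded. Compound 2 `S=C(Nc1ccc(Cl)cc1)Nc1nc2ccccc2s1` sits at a limit of this assay, > 50000 nM (the limit of > 50000 nM in this assay, at which 1 of the 2 values shown sits). Compound 3 `Fc1ccc2nc(Nc3nc4ccc(Cl)cc4s3)sc2c1` has not yet been measured. It differs from compound 1 in a single place (chloro in place of ethoxy on an aromatic carbon). Among the measured compounds shown here, no measured pair shows what this kind of exchange does in this assay, so neither the direction nor the size of the step can be read from the data. With nothing pointing to a large move either way, compound 3 is expected to land near compound 1, and the estimated step is a 1.1-fold lower number from compound 1 to compound 3 (0.04 log units; within the scatter), which stays within the usual scatter. Compound 3 is therefore estimated at 30000 nM, with a range from 10000 nM to 100000 nM.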

Compound 3, half-maximal inhibitory concentration: 41900 nM
Compound 3: the middle estimate sits 1.4-fold (0.15 log units) below what was measured; low and high end bracket the measured number.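

Among these compounds, this is the first step that can be read in this assay: chloro in place of ethoxy on an aromatic carbon gives a 1.3-fold higher number from compound 1 to compound 3 (0.10 log units; within the scatter). At this place, a group of 3 heavy atoms that includes an oxygen can therefore give way to a single chlorine without a shift that stands clear of the scatter, and neither group yields a strong inhibitor. The limit of the assay lies close to both numbers, which leaves little room to see any further weakening: the limit of > 50000 nM in this assay, at which 1 of the 3 values shown sits.

Going by these compounds, whether an amine, a carboxylic acid or a longer chain such as butoxy at this place would move the number beyond the scatter stays open. Among the compounds shown here, compound 2 differs from the others in more than one place, and no step to it can be read.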